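Growth inhibition notes: from compound 2 to compound 4

The compounds below may be only part of what the source reports. "The series", "measured", "known", "first", "only" and "open" are said of these compounds alone.

compound 1 `COc1cccc(/C=C/C(=O)/C=C/c2ccc(OCc3cn(CCOc4cc(=O)oc5ccccc45)nn3)c(OC)c2)c1` gives 13% as its reading
compound 2 `COc1ccc(/C=C/C(=O)/C=C/c2ccc(OCc3cn(CCCCCOc4cc(=O)oc5ccccc45)nn3)c(OC)c2)cc1` gives "not active" (no number reported) as its reading
compound 3 `COc1cc(/C=C/C(=O)/C=C/c2ccco2)ccc1OCc1cn(CCCCOc2cc(=O)oc3ccccc23)nn1` gives "not active" (no number reported) as its reading

All three readings come from a functional assay on PC-3 cells (Homo sapiens) for inhibition, read by sulforhodamine B assay, with a stated time of 48 h, tested at 50 uM (on this read-out higher numbers stand for more inhibition of growth at the one concentration tested and lower numbers for less inhibition of growth), and only compound 1 has a single number. Compound 2 has no single number and stands as "not active" (no number reported) in the reports, so it cannot be placed on a scale against compound 1. Compound 3 is the further entry without a number.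

The next compound is compound 4 `COc1cc(/C=C/C(=O)/C=C/c2ccco2)ccc1OCc1cn(CCCCCOc2cc(=O)oc3ccccc23)nn1` and the step from compound 2 is furan-2-yl in place of 4-methoxyphenyl on a double-bonded chain carbon bound to a double-bonded chain carbon with furan-2-yl in place of 4-methoxyphenyl on a double-bonded chain carbon bound to a double-bonded chain carbon. Within the data shown here, no measured pair here shows the size of such a change. Compound 3 also carries furan-2-yl and reads "not active" (no number reported) as its result, which is the ground for expecting no step beyond the scatter in this assay for this change.

Compound 4 is estimated at 8% in this assay with an expected range of 0% to 20% and a report without any number remains likely.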

Compound 4, percent growth inhibition at one concentration: "not active" (no number reported)
Compound 4 has no reported number here, and the estimate cannot be compared.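

In this assay compound 2 and compound 4 both stand without a single number, so no step can be read between them. No evidence bears on this result. The compounds shown leave open how furan-2-yl in place of 4-methoxyphenyl alters growth inhibition.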